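A few compounds are considered here, and "the series" means these few. Any claim that something is new, unique, unknown or untested is made for them only; others in the source may bear on it.

Among the measured compounds shown here, in an ADME assay on HEK-293T cells (Homo sapiens) for cytotoxicity, read by MTT assay, tested at 100 uM (a lower number here means a stronger effect, a higher number a weaker effect of the compound at the concentration tested), compound 2 `O=C(Nc1ncc([N+](=O)[O-])s1)c1cc(Cl)ccc1O` gives 63% and stands highest of the two numbers known here. For the measured compounds named here, compound 3 `CC(=O)Oc1ccc(Cl)cc1C(=O)Nc1ncc([N+](=O)[O-])s1` gives 31.2%, and the only step measured so far, a number 31.8 percentage points lower from compound 2 to compound 3 (beyond the scatter), came from acetyl in place of hydrogen on an oxygen on an aromatic ring. Compound 1 `O=C(Nc1ncc([N+](=O)[O-])s1)c1ccc(Cl)cc1O` has "not determined" (no result reported) in this assay, so it adds no number to the picture.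

Compound 4 `O=C(Nc1ncc([N+](=O)[O-])s1)c1cc(Cl)cc(Cl)c1O` differs from compound 2 in one place: chloro in place of hydrogen on an aromatic carbon. Going by the values given here, no measured step exchanges hydrogen for chloro on this ring, so the single step from compound 2 to compound 3 does not speak to the change at hand; it only shows that one alteration on this core moved the read-out by a large amount. With nothing that bears directly on a chloro group at this position, the more cautious expectation is that compound 4 stays near compound 2, with no step beyond the scatter. The step from compound 2 to compound 4 is therefore estimated as a number 5 percentage points lower from compound 2 to compound 4 (within the scatter). On that basis compound 4 is expected to give about 58% in this assay, within a range from 38% to 78%.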

Compound 4, a percentage reported as activity, at one concentration (the size of the read-out at that concentration, not a potency): 23.5%
Estimate against measurement, compound 4: 34.5 percentage points above; the whole stated range lies above it.
By their numbers in this assay, from the lowest: compounds 4 and 3 (each within the scatter of the next); then compound 2.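

In this assay, the step of a number 39.5 percentage points lower from compound 2 to compound 4 (beyond the scatter) shows that the aromatic carbon ortho to a hydroxy group and meta to a chloro group is not a silent place on this core: a single chloro in place of hydrogen there is enough for a large move towards a stronger effect at the concentration tested. Among the compounds shown here, the only earlier step, a number 31.8 percentage points lower from compound 2 to compound 3 (beyond the scatter), changed the hydroxy oxygen itself, whereas here the hydroxy group stays as it is and the change lies on a ring carbon, so the read-out of compound 2 now proves sensitive at two different places. Nothing at hand explains why a chloro group at this place has so large an effect.

Whether the effect is particular to chloro stays open, since no other group at this carbon, such as bromo, methyl, methoxy or an amine, appears among these compounds. For the compounds shown here, how the placement of the single chloro group matters also remains unsettled, as compound 1 gives "not determined" (no result reported) and so offers no number to set against compound 2.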